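The source may hold more compounds than are shown below. What is called first, only, known or untested is meant among the compounds shown, and "the series" means these compounds.

Compound 1 `O=C(CBr)Nc1ccc(C(=O)/C=C/c2ccc(Cl)cc2)cc1`, compound 2 `COc1ccc(/C=C/C(=O)c2ccc(NC(=O)CBr)cc2)cc1` and compound 3 `COc1ccc(/C=C/C(=O)c2ccc(NC(=O)C(C)Br)cc2)cc1` share one core and differ at two places. In a functional assay on the whole organism (strain albino) for inhibition, with Rattus norvegicus as the target, read by paw edema, with stated times of 30 min and 2 h, at a dose of 100 mg/kg by the oral route (a higher number here means more inhibition at the dose given (going by the name of the read-out), a lower number less inhibition), compound 1 gives 52%, compound 2 gives 42% and compound 3 gives 40%. Compound 2 stands second highest of the three numbers; its nearest neighbour is compound 3 and its furthest is compound 1, and both gaps lie within the scatter, so the three sit at one level in this assay. The step of a number 10 percentage points lower from compound 1 to compound 2 (within the scatter) put methoxy in place of chloro on an aromatic carbon; the step of a number 2 percentage points lower from compound 2 to compound 3 (within the scatter) put methyl in place of hydrogen on a saturated chain carbon bound to a bromine atom and a carbonyl carbon. Neither change moved this assay beyond the scatter.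

Compound 4 `COc1ccc(/C=C/C(=O)c2ccc(NC(=O)COc3ccc(C(C)=O)cc3)cc2)cc1` is not yet measured. It differs from compound 2 by 4-acetylphenoxy in place of bromo on a saturated chain carbon bound to a carbonyl carbon. For the measured compounds named here, of the measured steps only the one from compound 2 to compound 3 touches the same saturated chain carbon, and that step was within the scatter; no measured step removes the bromo or brings in a ring, so there is nothing to ground a larger shift. The expectation for this assay is therefore no step beyond the scatter, estimated as a number 2 percentage points lower from compound 2 to compound 4 (within the scatter). Compound 4 is expected to give 40%, with a range from 25% to 55%.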

Compound 4, a percentage reported as inhibition, in the whole organism at one dose (the size of the read-out at that dose, not a potency): 35%
Beside the measured number, compound 4's estimate is 5 percentage points above it; low and high end bracket the measured number.
By their numbers in this assay, from the lowest: compounds 4, 3, 2 and 1 (each within the scatter of the next, the first and the last beyond it).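

For the compounds shown here, replacing bromo with 4-acetylphenoxy on a saturated chain carbon bound to a carbonyl carbon is the first step here that removes the bromo and brings in a ring, and in this assay it gives a number 7 percentage points lower from compound 2 to compound 4 (within the scatter). The bromo is therefore not needed to keep compound 4 at the level of compound 2, even with 10 heavy atoms, including one six-membered aromatic ring of carbon only, entering where 1 heavy atom leaves. No evidence is available that bears on why the reading holds across this change.

Still open, as far as these compounds go, is whether an amine or a carboxylic acid in place of bromo on this carbon would also stay at this level, or whether a longer chain between the carbonyl carbon and the 4-acetylphenoxy group would shift the reading. Also open is whether 4-acetylphenoxy on this carbon would stay within the scatter with chloro rather than methoxy on the aromatic carbon, the other place where the compounds shown differ.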